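From 4-cyanophenyl to thiophen-2-yl on the shared core

This account rests on a few compounds, and the source may have more. Where it says the series, first, only, none or still open, it means among the compounds named here.

In a functional assay on HT-29 cells (Homo sapiens) for inhibition, with a stated time of 72 h (on this read-out lower numbers stand for stronger inhibition and higher numbers for weaker inhibition), compound 1 `COc1ccc(S(=O)(=O)N2CCc3cccc(-c4ccc(F)c(F)c4)c32)cc1` gives 57 nM, while compound 2 `COc1ccc(S(=O)(=O)N2CCc3cccc(-c4ccc(C#N)cc4)c32)cc1` gives 24.2 nM, the lower number of the two. Compound 3 `COc1ccc(S(=O)(=O)N2CCc3cccc(-c4cccs4)c32)cc1` carries thiophen-2-yl in place of 4-cyanophenyl on an aromatic carbon. Among the measured compounds shown here, only one measured step bears on this place, the modest 2.4-fold lower number from compound 1 to compound 2 (0.37 log units; beyond the scatter), and no measured compound carries thiophen-2-yl. A step of similar modest size toward a higher number is therefore expected in this assay, estimated as a 2.3-fold higher number from compound 2 to compound 3 (0.36 log units; beyond the scatter). For compound 3 the estimated value is 55 nM, with an expected range of 18 nM to 170 nM.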

Compound 3, half-maximal inhibitory concentration: 200 nM
Beside the measured number, compound 3's estimate is 3.6-fold (0.56 log units) below it, and the stated range ends below it.
By their numbers in this assay, from the lowest: compound 2; then compound 1; then compound 3.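

Thiophen-2-yl is the only five-membered aromatic ring at this place, and in this assay it gives an 8.3-fold higher number from compound 2 to compound 3 (0.92 log units; beyond the scatter) and a 3.5-fold higher number from compound 1 to compound 3 (0.55 log units; beyond the scatter) in the same series. Both steps lie beyond the scatter, so compound 3 has the highest number of the three, and neither phenyl-bearing compound reaches it. Nothing available explains this result. Going by these compounds, whether an amine or a carboxylic acid on the phenyl ring, or a morpholine ring in its place, would give a lower or a higher number remains open.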